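Trimming a Chain on a Fluorinated Aryl Compound

A few compounds are considered here, and "the series" means these few. Any claim that something is new, unique, unknown or untested is made for them only; others in the source may bear on it.

Measured in a functional assay on HL-60 cells (Homo sapiens) for inhibition, read by MTT assay, with a stated time of 72 h; on this read-out higher numbers stand for weaker inhibition and lower numbers for stronger inhibition:
- compound 1 `CCc1nc(-c2ccc(C(C)(C)C)cc2)c(C(=O)N2CCN(c3cccc(OC)c3)CC2)o1`: "not active" (no number reported)
- compound 2 `COc1cccc(N2CCN(C(=O)c3oc(C)nc3-c3ccccc3)CC2)c1`: 34.8 nM
- compound 3 `CCc1nc(-c2cccc(F)c2)c(C(=O)N2CCN(c3cccc(OC)c3)CC2)o1`: 201 nM

Only two of these compounds have a number. Compound 3 holds the higher one at 201 nM, which means the weaker inhibition of the pair. Compound 2 stands at 34.8 nM, and the gap between them lies beyond the usual scatter.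

Compound 4 `COc1cccc(N2CCN(C(=O)c3oc(C)nc3-c3cccc(F)c3)CC2)c1` has not yet been measured. It departs from compound 3 by a single change, hydrogen in place of methyl on a saturated chain carbon bound to an aromatic carbon. Cut one bond further out, the same difference reads ethyl to methyl.

Compound 2, which carries the same shorter methyl group, gives 34.8 nM, so a move toward a lower number seems likely. In this assay, the expected step of a 2.9-fold lower number from compound 3 to compound 4 (0.46 log units; beyond the scatter) is a moderate one toward stronger inhibition, though it may stay within the scatter. For compound 4 the estimated value is 70 nM, with an expected range from 25 nM to 220 nM.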

Compound 4, half-maximal inhibitory concentration: "not active" (no number reported)
Nothing numeric was reported for compound 4; the estimate stays without a comparison.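

In this assay, among these compounds, compound 4 gives "not active" (no number reported) and so no step from compound 3 can be read. No supporting evidence bears on this result. The compounds shown leave open how far ethyl to methyl alone shifts inhibition.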